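Methyl on the pyridine ring: effect on hepatic extraction

This account rests on a few compounds, and the source may have more. Where it says the series, first, only, none or still open, it means among the compounds named here.

Measured compounds:
- compound 1, `CC(=O)N1CCC[C@@H](Oc2cc(F)cc(NC(=O)Nc3cccnc3)c2)C1`: 0.5
- compound 2, `CC(=O)N1CCC[C@H](Oc2cc(F)cc(NC(=O)Nc3cccnc3)c2)C1`: "not determined" (no result reported)

Compound 1 stands alone on the numbers shown. In an ADME assay on microsomes from liver (Homo sapiens) (a higher number here means that the liver removes a larger share of the compound in one pass, a lower number that the liver removes a smaller share), compound 1 gives 0.5, meaning that roughly half of the compound is removed on a single pass through the liver. In this assay compound 2 gives "not determined" (no result reported), so nothing can be said of the pair beyond (the fact that compounds 1 and 2 differ only in the configuration as drawn).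

Compound 3, `CC(=O)N1CCC[C@@H](Oc2cc(F)cc(NC(=O)Nc3ccc(C)nc3)c2)C1`, is the next compound to be measured in this assay. Its difference from compound 1 is methyl in place of hydrogen on an aromatic carbon. The single added carbon sits on the pyridine ring, turning the pyridin-3-yl group into a 6-methylpyridin-3-yl group.

Among the compounds with values here, with no measured step between two compounds available, the size of the change in this assay can only be guessed. A single methyl on an aromatic carbon is a small alteration to the whole, so a step of a number 0.050 higher from compound 1 to compound 3 (within the scatter) is expected, close to the usual scatter and, if anything, slightly upward. Compound 3 is estimated to give 0.55, with a range from 0.4 to 0.7.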

Compound 3, hepatic extraction ratio: 0.6
Compound 3: middle estimate off by 0.050, on the low side; the range from low to high includes it.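

Within the data shown here, this is the first measured step, and it concerns the carbon next to the ring nitrogen, where pyridin-3-yl becomes 6-methylpyridin-3-yl: methyl in place of hydrogen gives a number 0.10 higher from compound 1 to compound 3 (within the scatter). In this assay, a step of this size cannot be told apart from what repeated measurements of one compound would give, so this position accepts one added carbon without a shift that the data can distinguish from noise. Nothing available bears on why the step has this size, and a single pair of compounds cannot show whether the small step is typical of this position.

The compounds shown leave open whether a larger group on the same carbon, such as an ethyl or a longer chain, or a group carrying other atoms, such as a methoxy or an amine, would give a step beyond the scatter in this assay. They also leave open whether methyl on the other carbons of the pyridine ring would behave as it does here.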